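A few compounds are considered here, and "the series" means these few. Any claim that something is new, unique, unknown or untested is made for them only; others in the source may bear on it.

Compound 1, `COc1cccc2cc(C(=O)NC3CCCCC3)c(=N)oc12`, gives 40%.
Compound 2, `COc1cccc2cc(C(=O)Nc3c(C#N)ncn3-c3ccc(F)cc3)c(=N)oc12`, gives 46%.
Compound 3, `O=C(NC1CCCC1)c1cc2ccccc2oc1=O`, gives 16%.

These three compounds were tested in an assay on CHO cells for displacement of a labelled ligand from adenosine receptor A1 (Homo sapiens), read by scintillation counting, with a stated time of 60 min, tested at 10 uM; on this read-out higher numbers stand for more inhibition at the one concentration tested (going by the name of the read-out) and lower numbers for less inhibition. On these numbers compound 2 stands highest of the three. Its nearest neighbour is compound 1, whose value lies within the usual scatter of this assay, so the two cannot be told apart. Compound 3 lies furthest away, beyond the scatter, so compound 2 does show more inhibition than compound 3.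

Compound 4, `COc1cccc2cc(C(=O)Nc3c(C#N)ncn3-c3ccccc3)c(=N)oc12`, has not yet been measured. It differs from compound 2 in one place: hydrogen in place of fluoro on an aromatic carbon. A single fluorine is removed from the aromatic ring and a hydrogen takes its place, while everything else in the molecule stays the same. Among the measured compounds shown here, no pair of measured compounds in this set differs by such a swap, so there is no direct precedent here for its effect. Because compound 2 gives 46% and the change is the loss of a single heavy atom, the step from compound 2 to compound 4 in this assay is expected to be small, most likely none beyond the scatter, in either direction. The estimate for compound 4 in this assay is therefore 42%, with a range from 25% to 60%, which means an expected step of a number 4 percentage points lower from compound 2 to compound 4 (within the scatter).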

Compound 4, a percentage reported as inhibition, at one concentration (the size of the read-out at that concentration, not a potency): 33%
The estimate for compound 4 lay 9 percentage points above the measured number, within the range that was stated.
By their numbers in this assay, from the lowest: compound 3; then compounds 4, 1 and 2 (each within the scatter of the next, the first and the last beyond it).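

Going from 4-fluorophenyl to phenyl in this assay gives a number 13 percentage points lower from compound 2 to compound 4 (beyond the scatter), and this is the first pair in the set that differs in one place only. It shows that this spot, on an aromatic carbon para to a large group, is not indifferent to what sits there: replacing one heavy atom with hydrogen is enough to give a real, if modest, loss of inhibition at the single concentration tested. Nothing among the available data points to a cause for this step.

The pair therefore shows that fluoro gives more inhibition than hydrogen at this place, but not how other groups would compare, so a chloro, a methyl, a methoxy or an amine there could fall on either side of these two compounds. It also leaves open whether the same swap would give a step of similar size on a compound with a different amide group, such as the cyclohexyl amide of compound 1.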